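A few compounds are considered here, and "the series" means these few. Any claim that something is new, unique, unknown or untested is made for them only; others in the source may bear on it.

For the measured compounds named here, in a functional assay on COR-L23 cells (Homo sapiens) for antiproliferative activity, read by CellTiter-Glo, with a stated time of 72 h (a lower number here means a stronger inhibitor, a higher number a weaker inhibitor), two compounds have numbers so far. Compound 1 (`C[C@@H](c1ccc(NC(=O)N2CC(c3ccc(N)nc3)C2)cc1)N1Cc2ccccc2C1=O`) gives 19 nM and compound 2 (`C[C@H](NC(=O)c1ncccn1)c1ccc(NC(=O)N2CC(c3ccc(N)nc3)C2)cc1`) gives 160 nM as its result, which makes compound 2 the weaker inhibitor of the pair.

Compound 3 (`C[C@H](NC(=O)[C@@H]1CCCN1C)c1ccc(NC(=O)N2CC(c3ccc(N)nc3)C2)cc1`) alters compound 2 at a single place, with 1-methylpyrrolidin-2-yl in place of pyrimidin-2-yl on a carbonyl carbon. A six-membered aromatic ring with 2 hetero atoms thus gives way to a five-membered non-aromatic ring with 1 hetero atom and a defined stereocentre.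

Going by the values given here, only one measured step offers any guide. It is an 8.4-fold higher number from compound 1 to compound 2 (0.93 log units; beyond the scatter) and it exchanged a larger group, one bond further out, so it bears on this change only loosely. Among the compounds with values here, it suggests how far a new group on the shared core can move the number, but no measured pair tests this swap directly, and the direction remains an uncertain call. A small rise, no larger than that earlier step, is expected (a 1.6-fold higher number from compound 2 to compound 3 (0.19 log units; within the scatter)). Compound 3 is estimated at 250 nM (range 50 nM to 1200 nM).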

Compound 3, half-maximal inhibitory concentration: 41 nM
Compound 3: middle estimate off by 6.1-fold (0.79 log units), on the high side; measured number below the stated range.
By their numbers in this assay, from the lowest: compound 1; then compound 3; then compound 2.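

Replacing pyrimidin-2-yl with 1-methylpyrrolidin-2-yl on the carbonyl carbon gives a 3.9-fold lower number from compound 2 to compound 3 (0.59 log units; beyond the scatter) in this assay and shows that an aromatic ring is not required at this place for a stronger result: the non-aromatic ring, with its single defined stereocentre, does better than the pyrimidine ring. The amide in compound 3 still does not fully match the group it stands in for on the shared core, with a 2.2-fold higher number from compound 1 to compound 3 (0.33 log units; beyond the scatter) and beyond the usual scatter, so this swap recovers much of the ground lost in compound 2 but not all of it. Nothing in the data shown explains why the number moves this way.

With only this one ring swap, the compounds shown do not separate the contribution of the ring nitrogen, its methyl group and the stereocentre. A pyrrolidin-2-yl group without the methyl, the mirror-image form of the 1-methylpyrrolidin-2-yl group, or an open-chain dimethylaminomethyl group on the same carbonyl carbon would tell these apart.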